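The source may hold more compounds than are shown below. What is called first, only, known or untested is meant among the compounds shown, and "the series" means these compounds.

Compound 1 `C[C@H](c1ccccc1)N1C(=O)O[C@](Cc2ccccc2)(c2nc(-c3ccccc3)co2)C1=O`: 15%
Compound 2 `C[C@H](c1ccccc1)N1C(=O)O[C@](Cc2ccccc2)(c2ncc(Cc3ccccc3)[nH]2)C1=O`: 0%

In an ADME assay (liver) for metabolic stability, with Liver microsome (Rattus norvegicus) as the target, using microsomes, with a stated time of 0.5 h, tested at 1 uM (a higher number here means that more of the compound is left, a lower number that less of the compound is left), compound 1 gives 15%, the higher of the two numbers. Compound 2 gives 0% in this assay, a number lower than that of compound 1 by more than the usual scatter. Compound 3 `C[C@H](c1ccccc1)N1C(=O)O[C@](Cc2ccccc2)(c2nnc(-c3ccccc3)o2)C1=O` has not yet been measured; it differs from compound 1 in one place: 5-phenyl-1,3,4-oxadiazol-2-yl in place of 4-phenyl-1,3-oxazol-2-yl on a saturated ring carbon. Going by the values given here, no measured pair shows this change, so the size of the step is open. The step of a number 5 percentage points higher from compound 1 to compound 3 (within the scatter) is expected to be small, at most a slight rise, within the scatter. Compound 3 is therefore estimated at 20%, with a range from 5% to 45%.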

Compound 3, percent of the compound remaining: 0%
Compound 3: middle estimate off by 20 percentage points, on the high side; the measured number lies below the stated range.
By their numbers in this assay, from the lowest: compounds 2 and 3 (each within the scatter of the next); then compound 1.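

In this assay, going by these compounds alone, the change at this saturated ring carbon, 5-phenyl-1,3,4-oxadiazol-2-yl in place of 4-phenyl-1,3-oxazol-2-yl, gives a number 15 percentage points lower from compound 1 to compound 3 (beyond the scatter) and is the first step read at this position. The two groups differ only by a nitrogen in place of a carbon in the five-membered aromatic ring, so even this small edit can shift the read-out. Nothing available explains the step. Still open, as far as these compounds go, is whether an amine or a carboxylic acid on this ring carbon would leave more compound in this assay and whether changing the 1-phenylethyl group would do the same.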